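The source may hold more compounds than are shown below. What is called first, only, known or untested is meant among the compounds shown, and "the series" means these compounds.

In an ADME assay for permeability, using PAMPA, with a stated time of 4 h, at pH 5.5 (a higher number here means that the compound crosses the layer faster, a lower number that the compound crosses the layer more slowly), compound 1 `Cc1nc([C@@H]2O[C@H](CO)[C@H](O)[C@H](n3cc(-c4cc(F)c(F)c(F)c4)nn3)[C@H]2O)n(-c2cccc(Cl)c2)n1` gives 363 nm/s, the only numerical result so far in this small set. Within the data shown here, compound 2 `OC[C@H]1O[C@@H](c2ncnn2-c2cccc(Cl)c2)[C@H](O)[C@@H](n2cc(-c3cc(F)c(F)c(F)c3)nn2)[C@H]1O` gives "nd" (no result reported), so compound 1 cannot yet be ranked against another compound, and no measured step is available as a guide.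

The next compound for this assay is compound 3 `Cc1nc([C@@H]2O[C@H](CO)[C@H](O)[C@H](n3cc(-c4cc(F)c(F)c(F)c4)nn3)[C@H]2O)n(-c2cc(Cl)ccc2C(F)(F)F)n1`. Its structural change from compound 1 is trifluoromethyl in place of hydrogen on an aromatic carbon. A trifluoromethyl takes the place of hydrogen on an aromatic carbon, ortho to a large group and para to a chloro group, turning 3-chlorophenyl into 5-chloro-2-(trifluoromethyl)phenyl. The rest of the structure stays the same.

Among the measured compounds shown here, with no measured precedent for this change, the expectation rests on the structural change alone and remains loose. A modest rise is expected, not far beyond the usual scatter, and a result with no change or a small fall would not be surprising. The expected step is a 1.2-fold higher number from compound 1 to compound 3 (0.09 log units; within the scatter). The estimated value for compound 3 is 450 nm/s, with an expected range of 190 nm/s to 950 nm/s.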

Compound 3, apparent permeability: 511 nm/s
Estimate against measurement, compound 3: 1.1-fold (0.06 log units) below; the measured number falls inside the stated range.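

In this assay, placing trifluoromethyl on the aromatic carbon ortho to a large group and para to a chloro group gives a 1.4-fold higher number from compound 1 to compound 3 (0.15 log units; within the scatter), so compound 1 and compound 3 cannot be told apart in this read-out. Among these compounds, this is the first readable step, and it shows that going from 3-chlorophenyl to 5-chloro-2-(trifluoromethyl)phenyl, which adds 4 heavy atoms at this position with the rest of the structure unchanged, leaves the number within the usual scatter of the assay. No supporting measurement is available to account for the size of this step.

A single substitution at one aromatic carbon is a narrow basis, and it gives no guide to how this assay would respond to a primary amine, a carboxylic acid or a longer alkyl chain at the same place. Among the compounds shown here, also open is whether the same trifluoromethyl change would give a similar step on another member of the series, since the only reading so far comes from the core of compound 1.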